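This account rests on a few compounds, and the source may have more. Where it says the series, first, only, none or still open, it means among the compounds named here.

Measured so far:
compound 1 `COc1cc(OC)c(/C=C/S(=O)(=O)Nc2ccc(OC)c(F)c2)c(OC)c1`: 75 nM
compound 2 `COC(=O)C(Nc1cc(NS(=O)(=O)/C=C/c2c(OC)cc(OC)cc2OC)ccc1OC)c1ccc(Cl)cc1`: 2500 nM

The read-out is a functional assay on K562 cells (Homo sapiens) for cytotoxicity, read by trypan blue exclusion, with a stated time of 96 h; on this read-out lower numbers stand for stronger inhibition and higher numbers for weaker inhibition. In this assay compound 2 gives 2500 nM, the higher of the two numbers, and its gap to compound 1 at 75 nM lies beyond the scatter.

Compound 3 `COc1cc(OC)c(/C=C/S(=O)(=O)Nc2ccc(OC)c(NC(C)(C)C(=O)O)c2)c(OC)c1` has not yet been measured. Relative to compound 2 it carries 1-carboxy-1-methylethyl in place of (4-chlorophenyl)(methoxycarbonyl)methyl on a nitrogen on an aromatic ring. For the measured compounds named here, no step between measured compounds covers this change, so the expectation rests on the two values alone. A move to a lower number in this assay, beyond the scatter, is expected, though probably not as far as compound 1 at 75 nM. The expected change is a 10-fold lower number from compound 2 to compound 3 (1.00 log units; beyond the scatter). For compound 3 the estimate is 250 nM, with an expected range of 40 nM to 2000 nM.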

Compound 3, half-maximal inhibitory concentration: 5 nM
Beside the measured number, compound 3's estimate is 50-fold (1.70 log units) above it; the measured number lies below the stated range.
By their numbers in this assay, from the lowest: compound 3; then compound 1; then compound 2.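

In this assay the group on a nitrogen on an aromatic ring now spans a wide range, with 1-carboxy-1-methylethyl in place of (4-chlorophenyl)(methoxycarbonyl)methyl giving a large step (a 500-fold lower number from compound 2 to compound 3 (2.70 log units; beyond the scatter)). Compound 2 alone left it unclear whether a substituted nitrogen here could match fluoro, yet (1-carboxy-1-methylethyl)amino in place of fluoro on an aromatic carbon also gives a large step (a 15-fold lower number from compound 1 to compound 3 (1.18 log units; beyond the scatter)), so this place tolerates a substituted nitrogen and reaches a lower number than fluoro. Nothing available explains the size of either step.

The change from compound 2 to compound 3 swaps the whole group at once, so the carboxylic acid, the two methyl groups and the loss of the 4-chlorophenyl ring cannot be separated. As far as these compounds go, how a carboxymethyl group, or the methyl ester of 1-carboxy-1-methylethyl, would read on this nitrogen stays open.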